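The source may hold more compounds than are shown below. What is called first, only, known or untested is meant among the compounds shown, and "the series" means these compounds.

Measured so far in a functional assay on NB1 cells (Homo sapiens) for antiproliferative activity, with a stated time of 72 h; a lower number here means a stronger inhibitor, a higher number a weaker inhibitor:

- compound 1, `CN(C)c1ccc(C(=O)N(CCC(=O)NCc2ccc(Cl)cc2)Cc2ccc(C(=O)NO)cc2)cc1`, gives 850 nM
- compound 2, `COc1ccc(C(=O)N(CCC(=O)NCc2ccccc2)Cc2ccc(C(=O)NO)cc2)cc1`, gives 2520 nM
- compound 3, `Cc1ccc(NC(=O)CCN(Cc2ccc(C(=O)NO)cc2)C(=O)c2ccc(N(C)C)cc2)cc1`, gives 660 nM

Among these three, compound 2 gives the highest number, that is, it is the weakest inhibitor of the set; its gaps to compound 1 and to compound 3 both lie beyond the usual scatter of repeated measurements, while compound 1 and compound 3 sit within the scatter of each other, as the step of a 1.3-fold lower number from compound 1 to compound 3 (0.11 log units; within the scatter) shows.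

The unmeasured compound 4, `Cc1ccc(C(=O)N(CCC(=O)NCc2ccccc2)Cc2ccc(C(=O)NO)cc2)cc1`, differs from compound 2 in one place: methyl in place of methoxy on an aromatic carbon. Cut one bond further out, the same difference reads 4-methoxyphenyl to 4-methylphenyl.

Among the compounds with values here, the only measured step, a 1.3-fold lower number from compound 1 to compound 3 (0.11 log units; within the scatter), changes a different part of the molecule and therefore says nothing about swapping the group on this aromatic carbon. Within the data shown here, compounds 1 and 3 carry a dimethylamino group in that place, but no pair isolates that group alone, so there is no measured basis for a shift in either direction. In this assay compound 4 is therefore expected to stay close to compound 2, with the expected step of a 1.1-fold lower number from compound 2 to compound 4 (0.06 log units; within the scatter) not beyond the scatter. The estimate for compound 4 is 2200 nM, with a range from 800 nM to 6000 nM.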

Compound 4, half-maximal inhibitory concentration: 1610 nM
The estimate for compound 4 lay 1.4-fold (0.14 log units) above the measured number; measured number inside the range.
By their numbers in this assay, from the lowest: compounds 3, 1, 4 and 2 (each within the scatter of the next, the first and the last beyond it).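

In this assay, within the data shown here, this is the first pair that changes only the group on this aromatic carbon, para to a large group, and it gives a 1.6-fold lower number from compound 2 to compound 4 (0.19 log units; within the scatter). Methoxy has 2 heavy atoms and 1 hydrogen-bond acceptor, whereas methyl has 1 heavy atom and 0 hydrogen-bond acceptors, yet this swap does not separate the two compounds beyond the ordinary spread of repeated measurements, so with the rest of the molecule held constant, the assay does not tell these two groups apart. No measured information is available to explain this result.

Among these compounds, it remains open how the dimethylamino group found at this place in compound 1 and compound 3 would compare with methoxy or methyl on an otherwise identical molecule, as no pair isolates that group. Also open, going by these compounds, are the results for quite different groups on this carbon, such as a carboxylic acid, a primary amine or a longer chain like butyl, and whether the methoxy-to-methyl swap would read the same alongside the 4-chlorobenzyl or 4-methylphenyl groups found elsewhere.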